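Swapping the amide-borne ring for a carboxypyridine

The source may hold more compounds than are shown below. What is called first, only, known or untested is meant among the compounds shown, and "the series" means these compounds.

Compound 1 `C=C(CC)C(=O)c1ccc(OCC(=O)Nc2nc3ccccc3s2)c(Cl)c1Cl`: 1500 nM
Compound 2 `C=C(CC)C(=O)c1ccc(OCC(=O)Nc2ccc3c(C)cc(=O)oc3c2)c(Cl)c1Cl`: 2800 nM
Compound 3 `C=C(CC)C(=O)c1ccc(OCC(=O)Nc2nc(/C(=N\OC)C(=O)O)cs2)c(Cl)c1Cl`: > 25000 nM

These three compounds were tested in a functional assay on CLL cells (Homo sapiens) for cytotoxicity, read by MTT assay, with a stated time of 48 h; a lower number here means that less compound is needed, a higher number that more compound is needed for the effect. Compound 1 gives the lowest of the two numbers, at 1500 nM. Compound 2 sits close by with 2800 nM, a gap that lies within the scatter, so the two cannot be ranked. Compound 3 gives no number at all in this assay, only a limit, > 25000 nM.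

The next compound, compound 4 `C=C(CC)C(=O)c1ccc(OCC(=O)Nc2ccc(C(=O)O)cn2)c(Cl)c1Cl`, keeps the shared core of compound 1 and changes a single place: 5-carboxypyridin-2-yl in place of 1,3-benzothiazol-2-yl on an amide-type nitrogen. The group that enters carries a carboxylic acid, a feature the measured compounds share only with compound 3.

Compound 4 is therefore expected to need more compound than compound 1, with the step of a 10-fold higher number from compound 1 to compound 4 (1.00 log units; beyond the scatter) estimated as beyond the scatter. Within the data shown here, this expectation rests on compound 3, the one measured compound with a carboxylic acid, which in this assay reaches only a limit, > 25000 nM. The estimate for compound 4 in this assay is 15000 nM, within a range from 4000 nM to 50000 nM.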

Compound 4, half-maximal effective concentration: 14900 nM
Compound 4: the middle estimate sits 1.0-fold (0.00 log units) above what was measured, within the range that was stated.
By their numbers in this assay, from the lowest: compounds 1 and 2 (each within the scatter of the next); then compound 4. At a limit, above all of these: compound 3.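

In this assay, placing 5-carboxypyridin-2-yl instead of 1,3-benzothiazol-2-yl on the amide-type nitrogen gives a 9.9-fold higher number from compound 1 to compound 4 (1.00 log units; beyond the scatter), so the group at this place clearly matters. A carboxylic acid here does not rule out a measurable effect, since compound 4 gives a real number, 14900 nM. Compound 3, the other compound with a carboxylic acid, gives only a limit of the assay: the limit of > 25000 nM in this assay, at which 1 of the 4 values shown sits.

This single change swaps the ring system and adds the carboxylic acid together, so the compounds shown cannot separate the contribution of the ring from that of the acid. A methyl ester in place of the carboxylic acid on the same six-membered ring would help to separate them.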